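The compounds below may be only part of what the source reports. "The series", "measured", "known", "first", "only" and "open" are said of these compounds alone.

Compound 1 `Cc1n[nH]c2ccc(-c3nc4cnc(N5CCN(C)CC5)cn4c3Nc3ccc(F)cc3)cc12`: 0%
Compound 2 `Cc1n[nH]c2ccc(-c3nc4cnc(N5CCN(C)CC5)cn4c3Nc3ccccc3Cl)cc12`: 58.1%
Compound 3 `Cc1n[nH]c2ccc(-c3nc4cnc(N5CCC(C)CC5)cn4c3Nc3ccc(Cl)cc3)cc12`: 28%

All three were tested in a functional assay on MV4-11 cells (Homo sapiens) for inhibition, with a stated time of 120 h, tested at 10 uM; on this read-out lower numbers stand for less inhibition and higher numbers for more inhibition at the one concentration tested (going by the name of the read-out). Compound 2 gives the highest of the three numbers, compound 3 stands below it and compound 1 lowest. Compound 4 `Cc1n[nH]c2ccc(-c3nc4cnc(N5CCN(C)CC5)cn4c3Nc3ccc(I)cc3)cc12` is still to be measured; it differs from compound 2 by 4-iodophenyl in place of 2-chlorophenyl on a nitrogen on an aromatic ring. Going by the values given here, the one measured step that bears on this is a number 58.1 percentage points higher from compound 1 to compound 2 (beyond the scatter), where 4-fluorophenyl became 2-chlorophenyl. The change to compound 4 goes back from 2-chlorophenyl to a 4-halophenyl, so a drop from compound 2 is expected, though iodine has not been tested here and compound 3, on a different core, gives 28%. Compound 4 is therefore estimated at 25%, with a range from 5% to 50%, which means an expected step of a number 33.1 percentage points lower from compound 2 to compound 4 (beyond the scatter).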

Compound 4, a percentage reported as inhibition, at one concentration (the size of the read-out at that concentration, not a potency): 0%
Compound 4: the middle estimate sits 25 percentage points above what was measured, outside the stated range (below it).
By their numbers in this assay, from the lowest: compounds 1 and 4 (each within the scatter of the next); then compound 3; then compound 2.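

In this assay, the change of fluoro to iodo on an aromatic carbon gives no change at the digits printed from compound 1 to compound 4 (within the scatter). Moving to 4-iodophenyl from 2-chlorophenyl on the same nitrogen gives a number 58.1 percentage points lower from compound 2 to compound 4 (beyond the scatter), so the two 4-halophenyl groups on this core read alike and both differ from 2-chlorophenyl. No measurement shown here gives a reason for this gap. Still open, from the compounds shown here alone, is whether the higher number of compound 2 follows the place of its halogen or chlorine itself. Plain phenyl and 2-fluorophenyl on the same core would bear on that.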